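Swapping a Methylsulfanylphenyl Arm for a Pyridinyl Arm

A few compounds are considered here, and "the series" means these few. Any claim that something is new, unique, unknown or untested is made for them only; others in the source may bear on it.

Three compounds share one core and differ only in the group on a carbon with a double bond to nitrogen. In a functional assay on HeLa cells (Homo sapiens) for cytotoxicity, read by MTT assay, with a stated time of 48 h, tested at 12.5 uM (on this read-out higher numbers stand for a stronger effect at the one concentration tested and lower numbers for a weaker effect), compound 1 `CS(=O)(=O)c1ccc(Cc2n[nH]c(=S)n2/N=C/c2c(F)cccc2Cl)cc1` gives 49.8%, compound 2 `CSc1ccc(/C=N/n2c(Cc3ccc(S(C)(=O)=O)cc3)n[nH]c2=S)cc1` gives 27.9%, and compound 3 `CS(=O)(=O)c1ccc(Cc2n[nH]c(=S)n2/N=C/c2ccc(F)cc2)cc1` gives 2.8%. Compound 2 thus stands second of the three, below compound 1 and above compound 3. Compound 4 `CS(=O)(=O)c1ccc(Cc2n[nH]c(=S)n2/N=C/c2cccnc2)cc1` is not yet measured; compared with compound 2 it carries pyridin-3-yl in place of 4-(methylsulfanyl)phenyl on a carbon with a double bond to nitrogen. The nearest guide is a number 25.1 percentage points lower from compound 2 to compound 3 (beyond the scatter), where the methylsulfanyl group was likewise lost, while a number 21.9 percentage points lower from compound 1 to compound 2 (beyond the scatter) shows that this group on the carbon matters throughout. A drop is therefore expected, a number 17.9 percentage points lower from compound 2 to compound 4 (beyond the scatter). Compound 4 is estimated at 10%, with a range from 0% to 30%.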

Compound 4, a percentage reported as activity, at one concentration (the size of the read-out at that concentration, not a potency): 16.9%
Compound 4: middle estimate off by 6.9 percentage points, on the low side; measured number inside the range.
By their numbers in this assay, from the lowest: compound 3; then compound 4; then compound 2; then compound 1.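

Pyridin-3-yl is the only arm here with a hetero atom in its aromatic ring, and in this assay it does not simply lower the number: the swap gives a fall against the 4-(methylsulfanyl)phenyl arm (a number 11 percentage points lower from compound 2 to compound 4 (beyond the scatter)) and a larger fall against the 2-chloro-6-fluorophenyl arm (a number 32.9 percentage points lower from compound 1 to compound 4 (beyond the scatter)), yet a rise against the 4-fluorophenyl arm (a number 14.1 percentage points higher from compound 3 to compound 4 (beyond the scatter)). A ring nitrogen at this carbon is thus tolerated, with a read-out that still sits clear of the lowest compound. Nothing available explains these shifts. Still open, going by these compounds, is how pyridin-2-yl or pyridin-4-yl would compare, and what an amine or a carboxylic acid on the phenyl arm would do.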